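The source may report more compounds than this note shows. Statements on the series, on what has been measured and on what is new or still open speak of the compounds shown alone.

In a functional assay on C8166 cells (Homo sapiens) for cytotoxicity, read by MTT assay (on this read-out higher numbers stand for lower toxicity in this test and lower numbers for higher toxicity in this test), compound 1 (`Cc1cc(S(N)(=O)=O)ccc1NC(=O)COc1ccc(Cl)cc1NC(=O)c1cccc([N+](=O)[O-])c1`) gives 58800 nM, compound 2 (`Cc1cc(S(N)(=O)=O)ccc1NC(=O)COc1ccc(Cl)cc1NC(=O)c1cccc(C(F)(F)F)c1`) gives 124000 nM and compound 3 (`Cc1cc(C)cc(C(=O)Nc2cc(Cl)ccc2OCC(=O)Nc2ccc(S(N)(=O)=O)cc2C)c1`) gives 36500 nM. Compound 3 thus sits clearly under compound 2 but cannot be told apart from compound 1. Compound 4 (`Cc1cc(S(N)(=O)=O)ccc1NC(=O)COc1ccc(Cl)cc1NC(=O)c1cc(Br)cc(Br)c1`) carries one change from compound 3: 3,5-dibromophenyl in place of 3,5-dimethylphenyl on a carbonyl carbon. Earlier swaps on this same ring were small: a 1.6-fold lower number from compound 1 to compound 3 (0.21 log units; within the scatter) stayed within the scatter, while a 3.4-fold lower number from compound 2 to compound 3 (0.53 log units; beyond the scatter) and a 2.1-fold higher number from compound 1 to compound 2 (0.32 log units; beyond the scatter) were modest. The new swap is therefore expected to move the number little, with no shift beyond the scatter. The expected change is a 1.3-fold higher number from compound 3 to compound 4 (0.12 log units; within the scatter). For compound 4 the estimate is 48000 nM, with an expected range of 22000 nM to 110000 nM.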

Compound 4, half-maximal cytotoxic concentration: 89700 nM
The estimate for compound 4 lay 1.9-fold (0.27 log units) below the measured number, within the range that was stated.
By their numbers in this assay, from the lowest: compounds 3, 1, 4 and 2 (each within the scatter of the next, the first and the last beyond it).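

In this assay the swap on this carbonyl carbon gives a 2.5-fold higher number from compound 3 to compound 4 (0.39 log units; beyond the scatter) and shows that 3,5-disubstituted rings can differ on this read-out even with their substituents in the same places. The steps of a 1.4-fold lower number from compound 2 to compound 4 (0.14 log units; within the scatter) and a 1.5-fold higher number from compound 1 to compound 4 (0.18 log units; within the scatter) leave compound 4 not distinguishable from either of those two compounds. No measurement here offers an explanation for the step from the dimethyl to the dibromo ring. As far as these compounds go, what an amine or a carboxylic acid on this ring would do remains open, as does whether the same swap would behave alike on a different core.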